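Methoxy for Trifluoromethyl: an Expected Loss of Potency

This account rests on a few compounds, and the source may have more. Where it says the series, first, only, none or still open, it means among the compounds named here.

Compound 1, `O=C(Nc1ccc(Cl)cc1)Nc1ccc(Nc2ncnc3c2OCCN3)cc1`, gives 2280 nM in an assay on isolated protein for inhibition of proto-oncogene tyrosine-protein kinase receptor Ret variant V804M (Homo sapiens), read by 33P incorporation, with stated times of 15 min and 40 min; a lower number here means a stronger inhibitor, a higher number a weaker inhibitor.
Compound 2, `O=C(Nc1ccc(Nc2ncnc3c2OCCN3)cc1)Nc1ccc(C(F)(F)F)cc1`, gives 276 nM in this assay.

Among the measured compounds shown here, of the two numbers measured, compound 2 stands lowest; its only neighbour is compound 1, and the single measured step is an 8.3-fold lower number from compound 1 to compound 2 (0.92 log units; beyond the scatter). Compound 3, `COc1ccc(NC(=O)Nc2ccc(Nc3ncnc4c3OCCN4)cc2)cc1`, differs from compound 2 by methoxy in place of trifluoromethyl on an aromatic carbon. For the measured compounds named here, only one measured step bears on this position at all, an 8.3-fold lower number from compound 1 to compound 2 (0.92 log units; beyond the scatter), and it concerns chloro giving way to trifluoromethyl, not trifluoromethyl giving way to methoxy. Going by the values given here, no measured pair shows what methoxy does here. The one step shown does say that exchanging the group at this place can move the number well beyond the scatter, and since trifluoromethyl is the group that gave the lowest number so far, its removal is expected to cost potency. For compound 3 in this assay the estimate is 1500 nM, within a range of 400 nM to 6000 nM. That estimate means an expected step of a 5.4-fold higher number from compound 2 to compound 3 (0.74 log units; beyond the scatter), a worsening, though the range is wide because nothing measured here involves methoxy.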

Compound 3, half-maximal inhibitory concentration: 824 nM
Beside the measured number, compound 3's estimate is 1.8-fold (0.26 log units) above it; the range from low to high includes it.
By their numbers in this assay, from the lowest: compound 2; then compound 3; then compound 1.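

Among the compounds shown here, the step of a 3.0-fold higher number from compound 2 to compound 3 (0.48 log units; beyond the scatter) gives the first measured reading for methoxy at this place, on an aromatic carbon para to a large group, and it shows that trifluoromethyl can be exchanged for methoxy with a loss that is beyond the scatter yet smaller than the gap separating the two earlier compounds. The step of a 2.8-fold lower number from compound 1 to compound 3 (0.44 log units; beyond the scatter) adds that methoxy is better here than chloro, so that the loss of trifluoromethyl does not by itself return the number to the level of compound 1, and the three groups now stand in this assay in the order trifluoromethyl, methoxy, chloro, from the lowest number to the highest. Nothing measured alongside these numbers accounts for that order.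

The compounds shown leave open how the parent phenyl without any group at this place would compare, and whether a nitrile, an amine, a carboxylic acid or a longer chain such as ethoxy would fall inside or outside this order. They also leave open whether the same order would hold if these groups stood on another carbon of the ring or were carried on a different core.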